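The source may hold more compounds than are shown below. What is called first, only, known or untested is meant among the compounds shown, and "the series" means these compounds.

Series notes. Compound 1 `Cc1cc(NC(=O)Cn2nnc(-c3ccccc3)n2)n(C2CCC(F)(F)CC2)n1`, compound 2 `Cc1cc(NC(=O)Cn2nnc(-c3ccccc3)n2)n(C(C)C)n1` and compound 3 `Cc1cc(NC(=O)Cn2nnc(-c3ccccc3)n2)n(C2CCS(=O)(=O)CC2)n1` share one core and differ only in the group on an aromatic nitrogen. In an assay on HEK293 cells for activation of Kir3.1/Kir3.2 (Homo sapiens), read by thallium flux (a higher number here means a larger maximal response, a lower number a smaller maximal response), compound 1 gives 68%. In this assay compound 2 gives 107%. For compound 3 the this assay reading is a limit, > 25%, and not a number. Of the steps, a number 39 percentage points higher from compound 1 to compound 2 (beyond the scatter) is the only one read in full. The steps a step that the limit leaves unreadable from compound 1 to compound 3 and a step that the limit leaves unreadable from compound 2 to compound 3 cannot be sized because the limit of > 25% in this assay, at which 1 of the 3 values shown sits, covers compound 3. Compound 4 `Cc1cc(NC(=O)Cn2nnc(-c3ccccc3)n2)n(CC2CCCCC2)n1` is not yet measured in this assay. It differs from compound 3 by cyclohexylmethyl in place of 1,1-dioxothian-4-yl on an aromatic nitrogen. Among the measured compounds shown here, no measured step removes a 1,1-dioxothian-4-yl group, so the nearest comparison is the change from 4,4-difluorocyclohexyl to isopropyl, which gave a number 39 percentage points higher from compound 1 to compound 2 (beyond the scatter). Compound 4 is therefore expected to give a readable number in this assay somewhere in the band spanned by compound 1 and compound 2. The estimate for compound 4 in this assay is 85%, with an expected range from 50% to 115%. The expected step that the limit leaves unreadable from compound 3 to compound 4 cannot be tied to a number for compound 3, whose value is only a limit.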

Compound 4, largest response reached (Emax), in percent of the reference or control that the assay uses: 77%
Compound 4: middle estimate off by 8 percentage points, on the high side, within the range that was stated.
By their numbers in this assay, from the lowest: compounds 1 and 4 (each within the scatter of the next); then compound 2.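

In this assay, cyclohexylmethyl on the aromatic nitrogen in place of isopropyl gives a number 30 percentage points lower from compound 2 to compound 4 (beyond the scatter), so the drop seen earlier with 4,4-difluorocyclohexyl is not confined to that one group. Cyclohexylmethyl in place of 4,4-difluorocyclohexyl gives a number 9 percentage points higher from compound 1 to compound 4 (within the scatter): at this position, moving from one carbon-only six-membered ring substituent to the other, with the fluorines gone and a carbon added before the ring, leaves the maximal response unchanged within the scatter, and compound 1 and compound 4 both sit apart from compound 2. Compound 3 carries a limit and not a number, and all steps that touch it, including the one to compound 4, cannot be read because of that single reading: the limit of > 25% in this assay, at which 1 of the 4 values shown sits.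

Still open, on these data alone, is whether the ring itself separates compound 1 and compound 4 from compound 2, a question that cyclopentyl, or an open chain such as n-butyl, on the same nitrogen would bear on. Also open, as far as these compounds go, is how a ring with a hetero atom compares with the carbon-only rings, since a readable number for the 1,1-dioxothian-4-yl group is missing and a piperidin-4-yl amine or a tetrahydropyran-4-yl ether would add to that comparison.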